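Swapping a chlorophenyl for a hydroxy-methoxyphenyl

A few compounds are considered here, and "the series" means these few. Any claim that something is new, unique, unknown or untested is made for them only; others in the source may bear on it.

Of the compounds shown here, two sharing one core have been tested in a functional assay on U-251 cells (Homo sapiens) for antiproliferative activity, read by MTT assay, with a stated time of 48 h; on this read-out higher numbers stand for weaker inhibition and lower numbers for stronger inhibition. Compound 1 `COc1ccc(-c2nc3cccc(-c4cc(OC)c(OC)c(OC)c4)c3o2)cc1F` gives 1700 nM. Within the data shown here, compound 2 `COc1cc(-c2cccc3nc(-c4cccc(Cl)c4)oc23)cc(OC)c1OC` gives 18500 nM, the highest of the two numbers, and the only step measured so far, an 11-fold higher number from compound 1 to compound 2 (1.04 log units; beyond the scatter), shows that exchanging the 3-fluoro-4-methoxyphenyl for a 3-chlorophenyl weakened the inhibition considerably. The next compound, compound 3 `COc1cc(-c2nc3cccc(-c4cc(OC)c(OC)c(OC)c4)c3o2)ccc1O`, has not yet been measured. Compared with compound 2, the difference is 4-hydroxy-3-methoxyphenyl in place of 3-chlorophenyl on an aromatic carbon. The 4-hydroxy-3-methoxyphenyl that enters resembles the 3-fluoro-4-methoxyphenyl of compound 1 more than it resembles the 3-chlorophenyl of compound 2, so the step from compound 1 to compound 2 is the one that bears on this change, and it was large. Reversing a change of that kind is expected to lower the number again, and the step expected in this assay is a 6.2-fold lower number from compound 2 to compound 3 (0.79 log units; beyond the scatter). For compound 3 the estimated value in this assay is 3000 nM, with a range from 700 nM to 13000 nM.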

Compound 3, half-maximal inhibitory concentration: 10300 nM
For compound 3 the middle estimate is 3.4-fold (0.54 log units) below the measured one, and the stated range covers the measured number.
By their numbers in this assay, from the lowest: compound 1; then compounds 3 and 2 (each within the scatter of the next).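

In this assay, the 4-hydroxy-3-methoxyphenyl, with its hydrogen-bond donor and two hydrogen-bond acceptors, cannot be told apart from the 3-chlorophenyl, which has none of these (a 1.8-fold lower number from compound 2 to compound 3 (0.25 log units; within the scatter)). At this carbon, next to the ring nitrogen and next to the ring oxygen, a methoxy and a hydroxy on the phenyl ring therefore do not restore the level of compound 1, whose 3-fluoro-4-methoxyphenyl remains clearly apart even though it also carries a methoxy (a 6.1-fold higher number from compound 1 to compound 3 (0.78 log units; beyond the scatter)). No supporting information is available to explain this gap, so the result describes the change without accounting for it.

The step between the two groups that carry a methoxy changes two things at once, the other substituent and the place of the methoxy on the ring, so the compounds shown cannot separate the contribution of each. Also open, on these data alone, is how this read-out would respond to a phenyl ring carrying an amine or a carboxylic acid, or to an unsubstituted phenyl ring, at the same carbon.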